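This account rests on a few compounds, and the source may have more. Where it says the series, first, only, none or still open, it means among the compounds named here.

Compound 1 `Nc1nc(O)c2c(n1)n(C1OC(CO)[C@@H](O)[C@H]1O)c(=O)n2Cc1ccc(Cl)cc1` holds the lower of the two numbers in hand: in a functional assay on the whole organism (B cells) with Mus musculus as the target (a higher number here means a larger maximal response, a lower number a smaller maximal response), compound 1 gives 15%, with compound 2 `C=CCn1c(=O)n(Cc2ccccc2)c2nc(N)nc(O)c21` nearest at 25%, a gap that lies within the scatter and so carries no ranking. Compound 3 `N#Cc1ccc(Cn2c(=O)n(C3OC(CO)[C@@H](O)[C@H]3O)c3nc(N)nc(O)c32)cc1` differs from compound 1 by cyano in place of chloro on an aromatic carbon. Among the measured compounds shown here, no measured pair carries this change, so its size is unknown, and the two values in hand point neither up nor down. The expected step is no change at the digits printed from compound 1 to compound 3 (within the scatter), none beyond the scatter. Compound 3 is accordingly estimated at 15%, within 5% to 30%.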

Compound 3, largest response reached (reported as maximal response), in percent of the reference or control that the assay uses: 50%
Compound 3: middle estimate off by 35 percentage points, on the low side, outside the stated range (above it).
By their numbers in this assay, from the lowest: compounds 1 and 2 (each within the scatter of the next); then compound 3.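

In this assay, cyano in place of chloro on this aromatic carbon, para to a large group, gives a number 35 percentage points higher from compound 1 to compound 3 (beyond the scatter). Among the compounds shown here, the group at this position therefore matters to the maximal response, and this is the first step to lie beyond the scatter. Nothing in hand accounts for the size of the step. A single pair cannot show how a carboxylic acid, an amine or a methoxy group on the same carbon would read. Also open, going by these compounds, is whether the same change would hold on the core of compound 2.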